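Amide variation on a catechol thiadiazole series: cytotoxicity notes

The compounds below may be only part of what the source reports. "The series", "measured", "known", "first", "only" and "open" are said of these compounds alone.

Measured compounds and values:
- compound 1, `O=C(Nc1nnc(-c2ccc(O)c(O)c2)s1)c1ccc(Cl)cc1`: 47300 nM
- compound 2, `CC(=O)Nc1nnc(-c2ccc(O)c(O)c2)s1`: 125000 nM
- compound 3, `O=C(COc1ccccc1)Nc1nnc(-c2cccc(O)c2O)s1`: 117000 nM

Compound 2 gives the highest number of the three in a functional assay on HeLa cells (Homo sapiens) for cytotoxicity, read by MTT assay, with a stated time of 72 h; a lower number here means a stronger inhibitor, a higher number a weaker inhibitor. Its nearest neighbour is compound 3, whose value in this assay is within the scatter of that of compound 2; the furthest is compound 1, which lies beyond the scatter. Among the measured compounds shown here, the one step measured across a single change is a 2.6-fold higher number from compound 1 to compound 2 (0.42 log units; beyond the scatter), a modest shift.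

The next compound, compound 4, `O=C(Nc1nnc(-c2ccc(O)c(O)c2)s1)c1ccccc1`, is not yet measured. It differs from compound 2 in one place: phenyl in place of methyl on a carbonyl carbon. This is close to the reverse of the measured step from compound 1 to compound 2, with the phenyl lacking the chlorine that compound 1 carries. For the measured compounds named here, the only bearing step is therefore a 2.6-fold higher number from compound 1 to compound 2 (0.42 log units; beyond the scatter), and on that basis a lower number for compound 4 is expected, of about the same size or somewhat smaller, since no measured compound shows what the chlorine alone contributes.

For compound 4 the expected outcome is a 2.1-fold lower number from compound 2 to compound 4 (0.32 log units; beyond the scatter), giving an estimate of 60000 nM in this assay, with a range from 25000 nM to 150000 nM.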

Compound 4, half-maximal inhibitory concentration: 23300 nM
Beside the measured number, compound 4's estimate is 2.6-fold (0.41 log units) above it; the whole stated range lies above it.
By their numbers in this assay, from the lowest: compound 4; then compound 1; then compounds 3 and 2 (each within the scatter of the next).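

Replacing methyl with phenyl on a carbonyl carbon gives a clear gain in this assay (a 5.4-fold lower number from compound 2 to compound 4 (0.73 log units; beyond the scatter)), so an aromatic ring at this position is linked to a lower number even without the chlorine of compound 1. Compound 4 also shows that the chlorine is not needed for this gain: hydrogen in place of chloro on an aromatic carbon goes further in the same direction (a 2.0-fold lower number from compound 1 to compound 4 (0.31 log units; beyond the scatter)), and the earlier step from compound 1 to compound 2 had left the contribution of the chlorine unseparated from that of the ring. No accompanying measurement accounts for either shift, so both stand as observations only.

Still open, on these data alone, is whether the gain needs an aromatic ring at all, since a cyclohexyl ring or a longer alkyl chain on the carbonyl carbon would separate ring type from size, and whether methoxy or an amine on the aromatic carbon that carries chloro in compound 1 would follow hydrogen or chloro. Compound 3 differs from the other compounds in more than one place, so it gives no reading of any single change in this series.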